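Exchanging the aryl amide of a hexafluoro-carbinol naphthalene series

The compounds below may be only part of what the source reports. "The series", "measured", "known", "first", "only" and "open" are said of these compounds alone.

Compound 1 `Cc1cccc(C(=O)Nc2c(C(O)(C(F)(F)F)C(F)(F)F)ccc3ccccc23)c1`: 23 nM
Compound 2 `O=C(Nc1c(C(O)(C(F)(F)F)C(F)(F)F)ccc2ccccc12)c1cccc([N+](=O)[O-])c1`: 117 nM

Two amides built on the same naphthalene core have been measured in an assay on LtK cells with ATP-sensitive inward rectifier potassium channel 11 (Homo sapiens) as the target; on this read-out higher numbers stand for an effect only at larger amounts of compound and lower numbers for an effect already at smaller amounts. Compound 1 gives 23 nM, while compound 2 gives 117 nM. Going by the values given here, compound 2 thus stands at the higher of the two numbers; the single measured step, a 5.1-fold higher number from compound 1 to compound 2 (0.71 log units; beyond the scatter), separates it from compound 1.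

The next compound, compound 3 `O=C(Nc1c(C(O)(C(F)(F)F)C(F)(F)F)ccc2ccccc12)c1ccc(Cl)cc1`, is reached from compound 2 by 4-chlorophenyl in place of 3-nitrophenyl on a carbonyl carbon. Among the compounds with values here, no measured step matches this exact exchange. Within the data shown here, the only step available, a 5.1-fold higher number from compound 1 to compound 2 (0.71 log units; beyond the scatter), shows that swapping one small group for another on the same aryl ring of the amide can move the number by a modest amount beyond the scatter, in either direction depending on which group is present. Since a nitro leaves and a chlorine enters, the expectation is that compound 3 returns toward the level of compound 1, so a step of a 2.9-fold lower number from compound 2 to compound 3 (0.47 log units; beyond the scatter) is estimated, with wide uncertainty. Compound 3 is therefore expected to give about 40 nM, within a range of 12 nM to 130 nM.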

Compound 3, half-maximal effective concentration: 570 nM
Beside the measured number, compound 3's estimate is 14-fold (1.15 log units) below it, and the stated range ends below it.
By their numbers in this assay, from the lowest: compound 1; then compound 2; then compound 3.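

In this assay, the aryl group on the carbonyl carbon proves able to shift the number much further than the first pair suggested: 4-chlorophenyl in place of 3-nitrophenyl gives a 4.9-fold higher number from compound 2 to compound 3 (0.69 log units; beyond the scatter) and 4-chlorophenyl in place of 3-methylphenyl gives a 25-fold higher number from compound 1 to compound 3 (1.39 log units; beyond the scatter) on the same core. Losing the nitro group therefore does not by itself bring the number back toward that of compound 1, and all three compounds now stand apart by steps beyond the scatter, with compound 1 lowest and compound 3 highest. The names show that this exchange alters both the group on the ring and the number of its ring position, and no measurement offered here explains why the number rises.

These three compounds cannot separate those two changes: 3-chlorophenyl and 4-methylphenyl would each alter only one of them relative to a compound already shown. Going by these compounds, it also remains open how the number would respond to an unsubstituted phenyl, or to an amine or a carboxylic acid on this ring.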